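Acrylamide chain extension on a quinazoline-type series, step to compound 4

The source may report more compounds than this note shows. Statements on the series, on what has been measured and on what is new or still open speak of the compounds shown alone.

Compound 3 `C=C(C)C(=O)Nc1cc2c(N3CCc4ccccc43)ncnc2cc1O[C@@H]1CCOC1` gives 4910 nM in a functional assay on PC-3 cells (Homo sapiens) for antiproliferative activity, read by MTT assay, with a stated time of 72 h; a lower number here means a stronger inhibitor, a higher number a weaker inhibitor. Among the three measured compounds it stands second highest, its nearest neighbour being compound 1 `C=C(C)C(=O)Nc1cc2c(N3CCc4ccccc43)ncnc2cc1OC`, which gives 4830 nM, and its furthest being compound 2 `COc1cc2ncnc(N3CCc4ccccc43)c2cc1NC(=O)C=C(C)C`, which gives 7840 nM; both separations lie within the scatter. Compound 4 `CC/C=C/C(=O)Nc1cc2c(N3CCc4ccccc43)ncnc2cc1O[C@@H]1CCOC1` differs from compound 3 by but-1-en-1-yl in place of 1-methylethenyl on a carbonyl carbon. Going by the values given here, the only measured step that touches the same position is a 1.6-fold higher number from compound 1 to compound 2 (0.21 log units; within the scatter), an exchange of the acyl group on the carbonyl carbon that left the number within the scatter. The other measured step, a 1.0-fold higher number from compound 1 to compound 3 (0.01 log units; within the scatter), concerns the oxygen substituent and does not bear on this change. Taken together, these steps give no ground to expect more than a small shift for compound 4, in no preferred direction. The step of a 1.2-fold higher number from compound 3 to compound 4 (0.09 log units; within the scatter) is therefore expected to stay within the scatter. Compound 4 is estimated at 6000 nM, with a range from 3000 nM to 12000 nM.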

Compound 4, half-maximal inhibitory concentration: 9590 nM
Compound 4: the middle estimate sits 1.6-fold (0.20 log units) below what was measured, within the range that was stated.
By their numbers in this assay, from the lowest: compounds 1, 3, 2 and 4 (each within the scatter of the next).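

In this assay, putting but-1-en-1-yl in place of 1-methylethenyl on the carbonyl carbon gives a 2.0-fold higher number from compound 3 to compound 4 (0.29 log units; within the scatter). Going by these compounds alone, this is the first step at this position with oxolan-3-yl rather than methyl on the oxygen, and the first to bring in but-1-en-1-yl; like the earlier exchange on the carbonyl carbon, it stays within the scatter, so neither exchange on this carbonyl carbon separates a pair of compounds. No measured evidence bears on this result.

The compounds shown leave open whether any group on this carbonyl carbon can carry the number beyond the scatter. A dimethylamino group at the end of the but-1-en-1-yl chain, a longer carbon chain or a plain ethenyl group could each test this.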